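Isobutyl for cyclopropyl on the aromatic nitrogen of compound 1

A few compounds are considered here, and "the series" means these few. Any claim that something is new, unique, unknown or untested is made for them only; others in the source may bear on it.

Compound 1 `O=C(O)c1cc(-c2cccc(COc3ccc4c(=O)n(C5CC5)sc4c3)c2)ccc1Cl` was tested in an assay on HEK293 cells for positive allosteric modulation of metabotropic glutamate receptor 2 (Rattus norvegicus), read by thallium flux (on this read-out lower numbers stand for an effect already at smaller amounts and higher numbers for an effect only at larger amounts of compound), where compound 1 gives 130 nM. Among the measured compounds shown here, the only other measured compound is compound 2 `COc1ccc(-c2cccc(COc3ccc4c(c3)CN(C3CCCC3)C4=O)c2)cc1C(=O)O`; in this assay compound 2 gives 170 nM. Compound 1 stands at the lowest of these two numbers, but the value of compound 2 lies within the scatter of it, so the two cannot be told apart on these data.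

Compound 3 `CC(C)Cn1sc2cc(OCc3cccc(-c4ccc(Cl)c(C(=O)O)c4)c3)ccc2c1=O` has not yet been measured. It differs from compound 1 in one place: isobutyl in place of cyclopropyl on an aromatic nitrogen. For the measured compounds named here, no pair of measured compounds shows a change of this kind, so there is no measured guide to its size or direction, and nothing else in the two measured values bears on the aromatic nitrogen.

Compound 3 is therefore expected to give about 200 nM in this assay, with a range from 60 nM to 700 nM. That estimate means a step of a 1.5-fold higher number from compound 1 to compound 3 (0.19 log units; within the scatter), expected to stay within the scatter or only a little beyond it.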

Compound 3, half-maximal effective concentration: 470 nM
Estimate against measurement, compound 3: 2.4-fold (0.37 log units) below; the range from low to high includes it.
By their numbers in this assay, from the lowest: compounds 1 and 2 (each within the scatter of the next); then compound 3.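

In this assay, among the compounds shown here, isobutyl in place of cyclopropyl on the aromatic nitrogen brings a 3.6-fold higher number from compound 1 to compound 3 (0.56 log units; beyond the scatter), the first measured change at this position. This shows that the group on this nitrogen can move the number beyond the scatter, and in this one pair the higher number goes with the ringless isobutyl rather than the three-membered ring of cyclopropyl. The data give no explanation for this step.

This single step cannot separate the loss of the ring from the change in the number of carbons, and a cyclobutyl or a straight propyl chain on the same nitrogen would bear on that. From the compounds shown here alone, how a group carrying an amine or a hydroxyl would fare at this position also remains open, as does whether the step holds on other cores.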